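The compounds below may be only part of what the source reports. "The series", "measured", "known", "first", "only" and "open" are said of these compounds alone.

Measured so far:
compound 1, `O=C(Cc1nn(C2CCNC2)c(=O)c2ccccc12)Nc1ccc(OC(F)(F)F)c(Cl)c1`: 16300 mL/min/kg
compound 2, `CCC(C(=O)O)c1nn(Cc2cn3cc(OCC4CC4)c(Cl)cc3n2)c2ccccc2c1=O`: < 56.7 mL/min/kg

Both compounds were tested in an ADME assay on microsomes from liver (Mus musculus) for metabolic stability; on this read-out lower numbers stand for slow clearance and higher numbers for fast clearance. Compound 1 clears fast, with 16300 mL/min/kg. Compound 2 gives no number at all: its result is a limit of the assay, < 56.7 mL/min/kg, so only the ceiling of its clearance is known, and it stands at the limit of < 56.7 mL/min/kg in this assay, at which 1 of the 2 values shown sits. For the measured compounds named here, no two measured compounds differ in a single place, so no measured step is available to lean on.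

Compound 3, `C[C@H](C(=O)O)c1nn(Cc2cn3cc(OCC4CC4)c(Cl)cc3n2)c2ccccc2c1=O`, has not yet been measured. It follows from compound 2 by one change: 1-carboxyethyl in place of 1-carboxypropyl on an aromatic carbon. The shared core and the acid-bearing chain on the aromatic carbon are kept, with the chain made shorter.

In this assay compound 3 is expected to clear slowly as well, and the estimate for compound 3 is 40 mL/min/kg, within 15 mL/min/kg to 120 mL/min/kg. The expected step that the limit leaves unreadable from compound 2 to compound 3 is none beyond the usual scatter, and a limit rather than a number is expected again.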

Compound 3, clearance in the Mus musculus assay: < 53.4 mL/min/kg
Compound 3: no number, only a limit; the forecaster's own chance of this, stated with the estimate: 65%; the middle value lies beyond the limit too.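

For the compounds shown here, in the Mus musculus assay, compound 2 and compound 3 each give only a limit, so no step between them can be read. In a physicochemical assay for solubility, measured as thermodynamic solubility, at pH 7.4 (a higher number here means a more soluble compound, a lower number a less soluble compound), compound 2 gives 359 ug/mL and compound 3 gives 892 ug/mL, which is a 2.5-fold higher number from compound 2 to compound 3 (0.40 log units; beyond the scatter). Going by these compounds, the actual clearance of each compound, and whether the two differ at all in the Mus musculus assay, stays open.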